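Chloroacetamide to crotonamide on the pyrazole series

The compounds below may be only part of what the source reports. "The series", "measured", "known", "first", "only" and "open" are said of these compounds alone.

Measured compounds:
compound 1, `C/C=C/C(=O)Nc1ccc(Cn2nc(-c3ccc(Oc4ccccc4)cc3)cc2C(=O)O)cc1`, > 60000 nM
compound 2, `CCOC(=O)c1cc(-c2ccc(Oc3ccccc3)cc2)nn1Cc1cccc(NC(=O)CCl)c1`, 500 nM
compound 3, `O=C(O)c1cc(-c2ccc(Oc3ccccc3)cc2)nn1C1CCCN(C(=O)CCl)C1`, 400 nM

In a functional assay on Maver1 cells (Homo sapiens) for inhibition, read by luminescence and CellTiter-Glo, with a stated time of 72 h (a higher number here means a weaker inhibitor, a lower number a stronger inhibitor), compound 2 gives 500 nM, the higher of the two numbers recorded, and the gap to compound 3 at 400 nM is within the scatter, so no order can be drawn between the two. For compound 1 the assay reports only a limit, > 60000 nM (the limit of > 60000 nM in this assay, at which 1 of the 3 values shown sits), and that compound differs from compound 2 in more than one place, so only the two values themselves can be set side by side.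

Compound 4, `C/C=C/C(=O)Nc1cccc(Cn2nc(-c3ccc(Oc4ccccc4)cc3)cc2C(=O)OCC)c1`, is not yet measured. It differs from compound 2 in one place: prop-1-en-1-yl in place of chloromethyl on a carbonyl carbon whose other neighbour is an amide-type nitrogen. Going by the values given here, no measured pair shows this change alone. Among the compounds with values here, compound 1, the only compound carrying the prop-1-en-1-yl carbonyl, sits at the limit, while both chloromethyl carbonyl compounds give numbers. On that basis the step from compound 2 to compound 4 is expected to go towards a weaker inhibitor, by a margin beyond the scatter, a 12-fold higher number from compound 2 to compound 4 (1.08 log units; beyond the scatter). Compound 4 is therefore estimated at 6000 nM in this assay, with a range of 1000 nM to 40000 nM, and a real chance that only a limit is returned.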

Compound 4, half-maximal inhibitory concentration: 14200 nM
Compound 4: the middle estimate sits 2.4-fold (0.37 log units) below what was measured; the measured number falls inside the stated range.
By their numbers in this assay, from the lowest: compounds 3 and 2 (each within the scatter of the next); then compound 4. At a limit, above all of these: compound 1.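

In this assay, going by these compounds alone, replacing chloromethyl with prop-1-en-1-yl on a carbonyl carbon whose other neighbour is an amide-type nitrogen gives a 28-fold higher number from compound 2 to compound 4 (1.45 log units; beyond the scatter), the first reading of this change on its own, and it shows that the series is sensitive to the group at this place. Compound 4 still returns a number, 14200 nM, so the prop-1-en-1-yl carbonyl does not in itself leave a compound of this series without one. Compound 1, the only other compound with this group, remains a limit and not a number: the limit of > 60000 nM in this assay, at which 1 of the 4 values shown sits.

As far as these compounds go, compound 1 differs from compound 4 in more than one place, so what separates their readings stays open, and the change itself rests on a single pair, with compound 2 as its only starting point. Also open, from the compounds shown here alone, is whether ethenyl in place of prop-1-en-1-yl, or a dimethylamino group at the end of the prop-1-en-1-yl chain, would keep the number closer to that of compound 2, 500 nM.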